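The source may report more compounds than this note shows. Statements on the series, on what has been measured and on what is new or still open speak of the compounds shown alone.

Working notes on the series. In an ADME assay on L02 cells (Homo sapiens) for inhibition, read by CCK-8 assay, with a stated time of 48 h (a lower number here means a stronger inhibitor of growth, a higher number a weaker inhibitor of growth), compound 1 (`CCN1CCN(c2ccc(Nc3ncc(Cl)c(Nc4ccccc4C)n3)nc2)CC1`) reads > 100000 nM, and this is a limit of the assay, not a number. Among the compounds with values here, compound 2 (`CN1CCN(c2ccc(Nc3ncc(Cl)c(Nc4ccccc4)n3)nc2)CC1`) gives 7990 nM, the only true number available so far in this assay. Within the data shown here, no measured step between compounds differing in one place exists yet, and compound 2 therefore cannot be ranked by any measured step.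

Compound 3 (`Cc1ccc(CNc2nc(Nc3ccc(N4CCN(C)CC4)cn3)ncc2Cl)cc1`) is still to be measured. Its difference from compound 2 is 4-methylbenzyl in place of phenyl on a nitrogen on an aromatic ring. In words, this is 4-methylbenzyl in place of phenyl on a nitrogen on an aromatic ring, which can also be read as anilino to (4-methylbenzyl)amino.

With compound 2 at 7990 nM as the sole numeric anchor, a modest move towards weaker growth inhibition is expected in this assay, with a higher number and a size only a little beyond the scatter. The expected step is a 2.3-fold higher number from compound 2 to compound 3 (0.35 log units; beyond the scatter). A reading that returns only a limit remains possible. For compound 3 the estimated value is 18000 nM, with an expected range of 6000 nM to 60000 nM.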

Compound 3, concentration for 50% growth inhibition: > 100000 nM
Compound 3: a limit, no number; the forecaster's own chance of this, stated with the estimate: 20%; middle value at least 5.5-fold (0.74 log units) from the limit.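

In this assay, within the data shown here, the exchange of phenyl for 4-methylbenzyl on a nitrogen on an aromatic ring gives an at least 12-fold higher number from compound 2 to compound 3 (1.09 log units; beyond the scatter) and is the first measured step, so this one change on this nitrogen is enough to move the reading from a number to a limit. Compound 3 reads > 100000 nM, which is a limit of the assay and not a number. As far as these compounds go, the step is therefore only a floor, and how much weaker compound 3 is as an inhibitor of growth stays unknown: the limit of > 100000 nM in this assay, at which 2 of the 3 values shown sit.

The change brings in the methyl group and the benzyl carbon together, so the compounds shown do not tell which of the two goes with the loss of growth inhibition, and this single pair supports no wider pattern for the position. A plain benzyl group on this nitrogen would separate the two parts of the change, while a phenyl ring carrying a 4-methyl group would test the methyl group alone.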